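This account rests on a few compounds, and the source may have more. Where it says the series, first, only, none or still open, it means among the compounds named here.

Measured so far:
- compound 1 `CCCC(=O)N1CC2CC(C1)N2`: in an assay on SH-EP1 cells for displacement of a labelled ligand from Neuronal acetylcholine receptor; alpha4/beta2 (Homo sapiens), read by scintillation counting (a lower number here means a stronger inhibitor, a higher number a weaker inhibitor), compound 1 gives 14 nM
- compound 2 `CC(C)C(=O)N1CC2CC(C1)N2`: in this assay compound 2 gives 130 nM

For the measured compounds named here, compound 2 stands at the higher of the two numbers, and the single measured step is a 9.3-fold higher number from compound 1 to compound 2 (0.97 log units; beyond the scatter). Compound 3 `O=C(C1CCC1)N1CC2CC(C1)N2` differs from compound 2 by cyclobutyl in place of isopropyl on a carbonyl carbon. Going by the values given here, the one measured step bears on this only loosely: it shows that a branched group in place of a straight chain on the carbonyl carbon raised the number in this assay, but no measured pair compares a ring with an open branched group, so the direction of the next step cannot be read from the data. A cyclobutyl keeps the branching point of the isopropyl while adding one carbon in a ring, and the expected change in this assay is therefore small, with a slight lean toward a lower number. Compound 3 is expected at 80 nM, within 25 nM to 300 nM. This estimated step is a 1.6-fold lower number from compound 2 to compound 3 (0.21 log units; within the scatter).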

Compound 3, inhibition constant: 16 nM
Compound 3: middle estimate off by 5.0-fold (0.70 log units), on the high side; the whole stated range lies above it.
By their numbers in this assay, from the lowest: compounds 1 and 3 (each within the scatter of the next); then compound 2.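

Cyclobutyl in place of isopropyl on the carbonyl carbon gives an 8.1-fold lower number from compound 2 to compound 3 (0.91 log units; beyond the scatter) in this assay, and this goes against reading the earlier step as a general rule that a branched group there raises the number, since the cyclobutyl is branched as well. Cyclobutyl in place of propyl gives a 1.1-fold higher number from compound 1 to compound 3 (0.06 log units; within the scatter), so in this assay the straight chain and the ring cannot be told apart, and among the three compounds only the isopropyl of compound 2 stands apart. No measurement at hand accounts for this difference between the isopropyl and the cyclobutyl.

The compounds shown leave open whether the low number extends to a cyclopropyl or cyclopentyl on the carbonyl carbon, or to a longer chain such as pentyl. They also leave open how a group carrying an amine or a hydroxyl would behave at this place.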